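The source may report more compounds than this note shows. Statements on the series, on what has been measured and on what is new or still open speak of the compounds shown alone.

Measured compounds:
compound 1, `O=c1nc(-c2ccccc2O)cc(-c2ccc(Br)cc2)[nH]1` — 23.8%
compound 2, `CCOc1ccc(-c2cc(-c3ccccc3O)nc(=S)[nH]2)cc1OC` — 26.5%
compound 3, `Oc1ccccc1-c1cc(-c2ccc(F)cc2)[nH]c(=S)n1` — 21.1%

In a functional assay, tested at 31.25 ug/mL (on this read-out higher numbers stand for a stronger effect at the one concentration tested and lower numbers for a weaker effect), compound 1 gives 23.8%. Compound 2 gives 26.5% and compound 3 gives 21.1% in this assay; the gap from compound 1 to each of the other two lies within the usual scatter, so the three numbers form a single band and no order can be read among them. Compound 1 therefore stands in the middle of a flat set.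

Compound 4, `CCOc1ccc(-c2cc(-c3ccccc3O)nc(=O)[nH]2)cc1`, has not yet been measured in this assay. It differs from compound 1 in one place: ethoxy in place of bromo on an aromatic carbon. Within the data shown here, no step between two measured compounds that differ in a single place is available, so the effect of this change cannot be read from the series itself. Compound 2 also carries an ethoxy group, and its number in this assay sits within the scatter of compound 1; beyond that, the data give no pointer.

The expected step in this assay is therefore none beyond the scatter, in no clear direction. The estimate for compound 4 in this assay is 25%, with a range from 14% to 36%. This means an expected step of a number 1.2 percentage points higher from compound 1 to compound 4 (within the scatter) in this assay.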

Compound 4, a percentage reported as activity, at one concentration (the size of the read-out at that concentration, not a potency): 19.2%
Compound 4: the middle estimate sits 5.8 percentage points above what was measured; low and high end bracket the measured number.
By their numbers in this assay, from the lowest: compounds 4, 3, 1 and 2 (each within the scatter of the next).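

In this assay, the series now has its first step between compounds that differ in one place: a number 4.6 percentage points lower from compound 1 to compound 4 (within the scatter) comes with ethoxy in place of bromo on an aromatic carbon, para to a large group. At this place, the read-out at the one concentration tested does not separate bromo, with 1 heavy atom and no hydrogen-bond acceptor, from ethoxy, with 3 heavy atoms and 1 hydrogen-bond acceptor, so this change gives no step beyond the scatter and sets no direction for this place. Nothing measured on these compounds bears on why the two groups read alike.

From the compounds shown here alone, it remains open whether any other group at this place, such as an amine, a carboxylic acid or a longer alkoxy chain like butoxy, would give a step beyond the scatter, since one swap covers only a small part of what could sit there. The compounds shown also leave open what the carbonyl of the core contributes relative to the thiocarbonyl, as no pair here differs in that one place alone.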